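The compounds below may be only part of what the source reports. "The series", "measured", "known", "first", "only" and "open" are said of these compounds alone.

Measured so far in a functional assay on the whole organism (strain Icem-CET (SPF Caw)) for inhibition, with Mus musculus as the target, with a stated time of 30 min; on this read-out higher numbers stand for an effect only at larger amounts of compound and lower numbers for an effect already at smaller amounts:
compound 1 `C/C(C(=O)NC1CC1)=C(\C)c1ccc(Br)cc1` gives 52.4 mg/kg
compound 2 `C#CCNC(=O)/C(C)=C(\C)c1ccc(OC)cc1` gives 112 mg/kg

Compound 2 stands with the higher of the two numbers, and compound 1 stands at a number that is lower by a margin beyond the usual scatter of repeated measurements. Not much more can be drawn from this pair: the two compounds differ from each other in several places at once, so the gap between them cannot be tied to any single change, and no pair of measured compounds differs in only one place.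

The step followed here leads from compound 2 to compound 3 `C#CCNC(=O)/C(C)=C(\C)c1ccccc1`. The change is hydrogen in place of methoxy on an aromatic carbon, para to a large group, with the rest of the molecule unchanged. Going by the values given here, no measured pair shows this particular change, so there is no measured step to lean on, only the knowledge that a small group is removed. In this assay the expected step is a 1.2-fold lower number from compound 2 to compound 3 (0.09 log units; within the scatter), a modest move toward a lower number at most, and possibly none beyond the scatter. Compound 3 is therefore estimated at 90 mg/kg, with a range from 45 mg/kg to 180 mg/kg.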

Compound 3, dose for half-maximal effect: 45.3 mg/kg
For compound 3 the middle estimate is 2.0-fold (0.30 log units) above the measured one, within the range that was stated.
By their numbers in this assay, from the lowest: compounds 3 and 1 (each within the scatter of the next); then compound 2.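

In this assay, going by these compounds alone, replacing methoxy with hydrogen on the aromatic carbon para to a large group gives a 2.5-fold lower number from compound 2 to compound 3 (0.39 log units; beyond the scatter) and this is the first change in these compounds that can be read on its own. It shows that the methoxy is not required at this place for the effect in the whole organism: compound 3, with no heavy atom there, has its effect at a smaller dose than compound 2. Nothing measured here explains this shift, so it stands as an observation without a known cause.

Going by these compounds, this single step compares only methoxy and hydrogen, so it remains open what a longer chain such as ethoxy, or an amine, would do at the same place on the ring. On these data alone, compound 1 carries bromine on the ring but also a different group on the amide nitrogen, so the effect of bromine at this place cannot be separated from that of the amide change, and it is also open whether the step seen here would hold with that other amide.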